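Fluorine for chlorines on the aryl ring: what to expect

The source may hold more compounds than are shown below. What is called first, only, known or untested is meant among the compounds shown, and "the series" means these compounds.

Compound 2 `O=[N+]([O-])c1cc(-c2nc(-c3ccc(Cl)c(Cl)c3)no2)cc(O)c1O` stands lowest of the two compounds measured in a functional assay on the whole organism (liver, strain NMRI) for inhibition, with Mus musculus as the target, with a stated time of 3 h, at a dose of 3 mg/kg by the oral route; a higher number here means more inhibition at the dose given (going by the name of the read-out), a lower number less inhibition: compound 2 gives 8.8%, while compound 1 `O=[N+]([O-])c1cc(-c2nc(-c3ccccc3)no2)cc(O)c1O` gives 20.6%. Going by the values given here, the one known step, a number 11.8 percentage points lower from compound 1 to compound 2 (beyond the scatter), bears directly on the change to compound 3 `O=[N+]([O-])c1cc(-c2nc(-c3ccc(F)cc3)no2)cc(O)c1O`, which carries 4-fluorophenyl in place of 3,4-dichlorophenyl on an aromatic carbon. Since removing both chlorines and adding a single fluorine partly undoes that earlier change, a modest rise, a number 7.2 percentage points higher from compound 2 to compound 3 (within the scatter), is expected, short of compound 1. Compound 3 is estimated at 16%, within 5% to 28%.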

Compound 3, a percentage reported as inhibition, in the whole organism at one dose (the size of the read-out at that dose, not a potency): 12.7%
Compound 3: the middle estimate sits 3.3 percentage points above what was measured; measured number inside the range.
By their numbers in this assay, from the lowest: compounds 2, 3 and 1 (each within the scatter of the next, the first and the last beyond it).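

In this assay there is a number 3.9 percentage points higher from compound 2 to compound 3 (within the scatter) and a number 7.9 percentage points lower from compound 1 to compound 3 (within the scatter) so at this position on the five-membered ring, 4-fluorophenyl cannot be told apart from either 3,4-dichlorophenyl or phenyl. Only compound 1 and compound 2 remain separated beyond the scatter, and compound 3 bridges that gap without joining either side. No evidence on the reason for these numbers is at hand. The compounds shown leave open whether a methoxy group or an amine on this aryl ring would give a number beyond the scatter of compound 1.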